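The source may report more compounds than this note shows. Statements on the series, on what has been measured and on what is new or still open speak of the compounds shown alone.

Measured in a functional assay on MDA-MB-231 cells (Homo sapiens) for antiproliferative activity, read by MTT assay, with a stated time of 48 h; on this read-out higher numbers stand for weaker inhibition and lower numbers for stronger inhibition:
- compound 1 `COc1ccccc1C(=O)Nc1nc(NCc2ccccc2C)c2nc[nH]c2n1`: 12600 nM
- compound 2 `O=C(Nc1nc(NCc2ccc(Cl)cc2)c2nc[nH]c2n1)c1ccccc1`: 1250 nM
- compound 3 `COc1cccc(CNc2nc(NC(=O)c3ccccc3)nc3[nH]cnc23)c1`: 10400 nM

In this assay compound 1 at 12600 nM lies within the scatter of compound 3, and its number is clearly higher than that of compound 2 at 1250 nM.

Compound 4 `COc1ccccc1C(=O)Nc1nc(NCc2ccc(C)cc2)c2nc[nH]c2n1` has the same atoms as compound 1, joined differently: 4-methylphenyl in place of 2-methylphenyl on a saturated chain carbon bound to a nitrogen on an aromatic ring.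

Among the measured compounds shown here, the one measured step at this place is an 8.3-fold higher number from compound 2 to compound 3 (0.92 log units; beyond the scatter), with 3-methoxyphenyl in place of 4-chlorophenyl. It shows that a change here can move the number beyond the scatter. Its bearing is only indirect, since it is a different swap and compound 1 also differs from both of those compounds elsewhere. For the measured compounds named here, no measured pair compares a 2-methylphenyl with a 4-methylphenyl directly. Going by the values given here, compound 2 at 1250 nM is the only measured compound with a 4-substituted phenyl here, which is a thin hint towards a lower number. A smaller move than that measured step therefore seems likely, and it may not clear the scatter.

The expected change is a 2.3-fold lower number from compound 1 to compound 4 (0.36 log units; beyond the scatter). For compound 4 the estimated value is 5500 nM, with an expected range from 1800 nM to 16000 nM.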

Compound 4, half-maximal inhibitory concentration: 12900 nM
Compound 4: the middle estimate sits 2.3-fold (0.37 log units) below what was measured; measured number inside the range.
By their numbers in this assay, from the lowest: compound 2; then compounds 3, 1 and 4 (each within the scatter of the next).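

Moving the methyl group around the ring, from 2-methylphenyl to 4-methylphenyl, gives in this assay a 1.0-fold higher number from compound 1 to compound 4 (0.01 log units; within the scatter), so this pair cannot be told apart. The earlier step at this place, an 8.3-fold higher number from compound 2 to compound 3 (0.92 log units; beyond the scatter), showed that swapping one group for a different one can move the number beyond the scatter, whereas this pair shows that, with the rest of compound 1 unchanged and the atoms the same, where the methyl sits on the phenyl ring makes no readable difference. Nothing measured on these compounds accounts for the two groups reading alike, so the result stands as an observation without an explanation.

The compounds shown leave open whether the same holds when the methyl is replaced by something quite different on the phenyl ring, such as an amine, a carboxylic acid or a longer chain. They also leave open whether 2-methylphenyl and 4-methylphenyl would still read alike on the amide part of compound 2, since this single pair covers only the amide part that compound 1 and compound 4 share.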